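A few compounds are considered here, and "the series" means these few. Any claim that something is new, unique, unknown or untested is made for them only; others in the source may bear on it.

Values in a functional assay on the whole organism for antagonist activity, with Mus musculus as the target; a lower number here means that less compound is needed, a higher number that more compound is needed for the effect:
- compound 1 `CC(=O)N(C)CC#CCn1cncc1C`: > 100 mg/kg (a limit)
- compound 2 `COC(=O)N(C)CC#CCn1cncc1C`: 5.4 mg/kg
- compound 3 `CN(C)C(=O)N(C)CC#CCn1ccnc1`: > 100 mg/kg (a limit)

Compound 3 gives only a limit, and stands at the limit of > 100 mg/kg in this assay, at which 2 of the 3 values shown sit. Compound 4 `Cc1cncn1CC#CCN(C)C(=O)N(C)C` is compound 3 with methyl in place of hydrogen on an aromatic carbon.

Among the measured compounds shown here, the one measured step, an at least 18-fold lower number from compound 1 to compound 2 (1.26 log units; beyond the scatter), is methoxy in place of methyl on a carbonyl carbon. It lies elsewhere in the structure and gives no size for this change. Compound 1 carries the same ring methyl and still reports > 100 mg/kg, which is a limit. Little change is therefore expected in this assay, and no direction can be given with confidence. The expected step is a number no higher from compound 3 to compound 4 (the limit leaves the size open), not clearly beyond the scatter. For compound 4 the estimated value is 100 mg/kg, with an expected range of 20 mg/kg to 400 mg/kg.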

Compound 4, dose for half-maximal effect: 11.8 mg/kg
Compound 4: middle estimate off by 8.5-fold (0.93 log units), on the high side; measured number below the stated range.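

In this assay, as far as these compounds go, methyl in place of hydrogen on the aromatic carbon now has a measured effect (an at least 8.4-fold lower number from compound 3 to compound 4 (0.92 log units; beyond the scatter)), though its full size stays open: the limit of > 100 mg/kg in this assay, at which 2 of the 4 values shown sit. With the ring methyl kept, the group on the carbonyl carbon also counts: dimethylamino in place of methyl gives a clear gain (an at least 8.4-fold lower number from compound 1 to compound 4 (0.92 log units; beyond the scatter)), while dimethylamino in place of methoxy gives a modest loss (a 2.2-fold higher number from compound 2 to compound 4 (0.34 log units; beyond the scatter)).

Open, from the compounds shown here alone, is whether an ethyl or a chlorine on that aromatic carbon would serve as the methyl does. Also open, going by these compounds, is the size of the methyl step with methoxy on the carbonyl carbon.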